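Adding a hydroxy to the core of compound 1

The source may hold more compounds than are shown below. What is called first, only, known or untested is meant among the compounds shown, and "the series" means these compounds.

In a functional assay on MCF7 cells (Homo sapiens) for cytotoxicity, read by MTT assay, with a stated time of 48 h (a higher number here means a weaker inhibitor, a lower number a stronger inhibitor), the measured compounds give these values:
Compound 1 `COc1cc(/C=C/C(=O)/C=C/c2nc3ccccc3n2C)ccc1O` gives 3700 nM
Compound 2 `COc1cc(/C=C/C(=O)/C=C/c2nc3c(C)cccc3n2C)ccc1O` gives 3500 nM
Compound 3 `COc1ccc2c(c1)nc(/C=C/C(=O)/C=C/c1ccc(O)c(OC)c1)n2C` gives 3900 nM

Compound 1 stands level with the other two, all three lying within the scatter of one another. Compound 4 `COc1cc(/C=C/C(=O)/C=C/c2nc3cc(O)ccc3n2C)ccc1O` departs from compound 1 in one place, with hydroxy in place of hydrogen on an aromatic carbon. For the measured compounds named here, two measured steps bear on this, the methyl change (a 1.1-fold lower number from compound 1 to compound 2 (0.02 log units; within the scatter)) and the methoxy change (a 1.1-fold higher number from compound 1 to compound 3 (0.02 log units; within the scatter)), and neither leaves the scatter. Going by the values given here, no measured step places a hydroxy on the core, so this reading remains uncertain. No step beyond the scatter is therefore expected in this assay for this change. The expected step is a 1.1-fold lower number from compound 1 to compound 4 (0.04 log units; within the scatter) in size. Compound 4 is estimated at 3400 nM with an expected range from 1700 nM to 6500 nM in this measurement.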

Compound 4, half-maximal inhibitory concentration: 2900 nM
Compound 4: middle estimate off by 1.2-fold (0.07 log units), on the high side; low and high end bracket the measured number.
By their numbers in this assay, from the lowest: compounds 4, 2, 1 and 3 (each within the scatter of the next).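

In this assay, hydroxy in place of hydrogen on this aromatic carbon of the core stays within the scatter, a 1.3-fold lower number from compound 1 to compound 4 (0.11 log units; within the scatter). Taking the methyl off the oxygen at the same place also stays within the scatter, a 1.3-fold lower number from compound 3 to compound 4 (0.13 log units; within the scatter), so hydrogen, methoxy and hydroxy there all read level. Nothing shown here offers an explanation for these small steps. From the compounds shown here alone, whether an amine or a carboxylic acid on this carbon would move the number beyond the scatter remains open. So does whether a longer chain on the oxygen would do so.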